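The source may hold more compounds than are shown below. What is called first, only, known or untested is meant among the compounds shown, and "the series" means these compounds.

Series of compounds sharing the core of compound 1 `COC(=O)c1c(O)c2ccccc2n(C)c1=O`, all tested in an assay on isolated protein for inhibition of seed linoleate 13S-lipoxygenase-1 (Glycine max), tested at 0.1 mM; a higher number here means more inhibition at the concentration tested (going by the name of the read-out), a lower number less inhibition. Compound 1 gives 72.4%. Compound 2 `Cn1c(=O)c(C(=O)NCCN)c(O)c2ccccc21` carries (2-aminoethyl)amino in place of methoxy on the carbonyl carbon; in this assay compound 2 gives 99.5%, the highest of the three numbers, reached with a number 27.1 percentage points higher from compound 1 to compound 2 (beyond the scatter). Compound 3 `NCCNC(=O)c1c(O)c2ccccc2n(-c2ccccc2)c1=O` differs from compound 2 by phenyl in place of methyl on the aromatic nitrogen; compound 3 gives 82.3%, the nearest number to compound 2, with a number 17.2 percentage points lower from compound 2 to compound 3 (beyond the scatter).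

Compound 4 `Cn1c(=O)c(C(=O)NCCCCCCN)c(O)c2ccccc21` is reached from compound 2 by 4-aminobutyl in place of amino on a saturated chain carbon, two bonds along the chain from an amide-type nitrogen. Neither measured step concerns the chain between the amide-type nitrogen and the terminal amino: the step from compound 1 to compound 2 exchanges the group on the carbonyl carbon, the step from compound 2 to compound 3 the group on the aromatic nitrogen. Both lie beyond the scatter, but the amide with a terminal amino that marks compound 2 is kept in compound 4. The number of compound 2 sits near the top of the percentage scale, leaving little room upward; the expected step of a number 9.5 percentage points lower from compound 2 to compound 4 (within the scatter) is therefore small, downward or none beyond the scatter. Compound 4 is expected to give 90%, in the range 72% to 100%.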

Compound 4, a percentage reported as inhibition, at one concentration (the size of the read-out at that concentration, not a potency): 92.1%
The estimate for compound 4 lay 2.1 percentage points below the measured number; measured number inside the range.
By their numbers in this assay, from the lowest: compounds 1, 3, 4 and 2 (each within the scatter of the next, the first and the last beyond it).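

In this assay the step of a number 7.4 percentage points lower from compound 2 to compound 4 (within the scatter) comes with 4-aminobutyl in place of amino on a saturated chain carbon, two bonds along the chain from an amide-type nitrogen. For the compounds shown here, the earlier steps changed only the group on the carbonyl carbon and the group on the aromatic nitrogen, so this is the first reading on the chain itself: 2-aminoethyl and 6-aminohexyl cannot be told apart here. Compound 2 sits near the top of the percentage scale, so this single-concentration comparison has little room to separate the two chains. No measurement at hand accounts for this outcome. As far as these compounds go, whether a longer chain keeps the number within the scatter of compound 2 remains open. Also open, from the compounds shown here alone, is what a hydroxyl group or a carboxylic acid would do in place of the terminal amino.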